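The source may hold more compounds than are shown below. What is called first, only, known or untested is meant among the compounds shown, and "the series" means these compounds.

In a functional assay on A549 cells (Homo sapiens) for inhibition, read by MTT assay, with a stated time of 72 h (on this read-out lower numbers stand for stronger inhibition and higher numbers for weaker inhibition), compound 1 `CC(C)(C)n1cc2c(n1)C(=O)CC1(CCN(C(=O)c3cc(-c4ccc(Br)cc4)nc4ccccc34)CC1)O2` gives 9300 nM. Compound 2 `COc1cc(C(=O)N2CCC3(CC2)CC(=O)c2nn(C(C)(C)C)cc2O3)c2ccccc2n1` stands at > 10000 nM, which is a limit of the assay and not a number. The evidence on the measured steps is thin: the limit of > 10000 nM in this assay, at which 1 of the 2 values shown sits.

Compound 3 `CCOc1cc(C(=O)N2CCC3(CC2)CC(=O)c2nn(C(C)(C)C)cc2O3)c2ccccc2n1` differs from compound 2 as follows: methyl in place of hydrogen on a saturated chain carbon bound to an oxygen on an aromatic ring. This is methyl in place of hydrogen on a saturated chain carbon bound to an oxygen on an aromatic ring, that is, methoxy to ethoxy.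

Going by the values given here, the one measured step that bears on this, methoxy in place of 4-bromophenyl on an aromatic carbon, is an at least 1.0-fold higher number from compound 1 to compound 2 (0.03 log units; that floor lies within the scatter). It is only a floor within the scatter, so no step beyond the scatter is expected in this assay, and no direction can be favoured.

For compound 3 the estimated value is 12000 nM, with an expected range from 6000 nM to 25000 nM. This estimate means an expected step that the limit leaves unreadable from compound 2 to compound 3.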

Compound 3, half-maximal inhibitory concentration: > 10000 nM
Compound 3 ended at the assay's limit; the forecaster's own chance of this, stated with the estimate: 75%; the middle value is on the limit's open side.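

In this assay compound 3 gives > 10000 nM, which is a limit of the assay and not a number, and the extra methyl on the methoxy group brings no readable value at this position. Compound 2 also stands at a limit, so the step from methoxy to ethoxy cannot be read, while the exchange of 4-bromophenyl for ethoxy gives an at least 1.0-fold higher number from compound 1 to compound 3 (0.03 log units; that floor lies within the scatter). Methoxy and ethoxy at this carbon now both end at the limit, and the evidence on the series remains narrow: the limit of > 10000 nM in this assay, at which 2 of the 3 values shown sit.

From the compounds shown here alone, whether a longer chain such as propoxy, or an amine in place of the ethoxy, gives a readable value at this carbon stays open. Also open, going by these compounds, is how far any aryl group other than the 4-bromophenyl of compound 1, at 9300 nM, would differ from it.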